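The source may report more compounds than this note shows. Statements on the series, on what has been measured and on what is new or still open speak of the compounds shown alone.

Of the compounds shown here, three sharing one core have been measured in an assay on HEK293 cells for binding affinity to 5-hydroxytryptamine receptor 7 (Homo sapiens), read by radioligand binding; a lower number here means a stronger inhibitor, a higher number a weaker inhibitor. Compound 1 `CC(C)(C)CN1CCCN(CCn2ccc3ccc(Br)cc32)CC1` gives 163 nM, compound 2 `Brc1ccc2ccn(CCN3CCCN(CC4CC4)CC3)c2c1` gives 9 nM, and compound 3 `Brc1ccc2ccn(CCN3CCCN(C4CCCC4)CC3)c2c1` gives 10 nM. Compound 3 thus sits close to compound 2, the two values lying within the scatter, whereas a 16-fold lower number from compound 1 to compound 3 (1.21 log units; beyond the scatter) marks a large gap. Compound 4 `Brc1ccc2ccn(CCN3CCCN(C4CCCCC4)CC3)c2c1` carries cyclohexyl in place of cyclopentyl on an amine nitrogen in a ring. Among the measured compounds shown here, the closest precedent is a 1.1-fold higher number from compound 2 to compound 3 (0.05 log units; within the scatter), an exchange of one ring-bearing group for another that left the number within the scatter, while an 18-fold lower number from compound 1 to compound 2 (1.26 log units; beyond the scatter) and a 16-fold lower number from compound 1 to compound 3 (1.21 log units; beyond the scatter), both large, involved the branched groups instead. A step no larger than the scatter is therefore expected in this assay. For compound 4 the estimated step is a 1.2-fold higher number from compound 3 to compound 4 (0.08 log units; within the scatter). Compound 4 is expected to give 12 nM, within 5 nM to 30 nM.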

Compound 4, inhibition constant: 17 nM
The estimate for compound 4 lay 1.4-fold (0.15 log units) below the measured number; low and high end bracket the measured number.
By their numbers in this assay, from the lowest: compounds 2, 3 and 4 (each within the scatter of the next); then compound 1.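

In this assay, cyclohexyl in place of cyclopentyl on the ring amine nitrogen gives a 1.7-fold higher number from compound 3 to compound 4 (0.23 log units; within the scatter), and cyclohexyl in place of cyclopropylmethyl gives a 1.9-fold higher number from compound 2 to compound 4 (0.28 log units; within the scatter), so this position accepts a six-membered carbon ring with no change beyond the scatter. Replacing neopentyl with cyclohexyl gives a 9.6-fold lower number from compound 1 to compound 4 (0.98 log units; beyond the scatter), so among these four compounds neopentyl alone stands apart from the other groups. Nothing available explains these differences. Still open, as far as these compounds go, is whether a phenyl or tetrahydropyranyl ring at this nitrogen would keep the number in the same range.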